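Inverting both ring stereocentres of compound 2

The compounds below may be only part of what the source reports. "The series", "measured", "known", "first", "only" and "open" are said of these compounds alone.

Values in a functional assay on FL5.12 cells (Mus musculus) for cytotoxicity, read by flow cytometry, with a stated time of 48 h (on this read-out lower numbers stand for stronger inhibition and higher numbers for weaker inhibition), for the series
- compound 1 `CCCCCCc1ccc(CO[C@@H]2CN[C@@H](CO)C2)cc1` gives 2700 nM
- compound 2 `CCCC/C=C/c1ccc(CO[C@@H]2CN[C@@H](CO)C2)cc1` gives 5500 nM
- compound 3 `CCCCCCCCCC/C=C/c1ccc(CO[C@@H]2CN[C@@H](CO)C2)cc1` gives 2800 nM

Compound 2 at 5500 nM holds the highest of the three numbers, but it is separated from the others only by small steps. Hex-1-en-1-yl in place of hexyl on an aromatic carbon gives a 2.0-fold higher number from compound 1 to compound 2 (0.31 log units; beyond the scatter) as a modest change. Hexyl in place of hydrogen on a saturated chain carbon gives a 2.0-fold lower number from compound 2 to compound 3 (0.29 log units; within the scatter) and so does not separate those two compounds.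

The next compound to be tested is compound 4 `CCCC/C=C/c1ccc(CO[C@H]2CN[C@H](CO)C2)cc1` and it differs from compound 2 by the two compounds have the same atoms and bonds and differ only in configuration as drawn: 2 of 3 stereo elements differ; a stereocentre at a saturated ring carbon is drawn S in compound 2 and R in compound 4; a stereocentre at a saturated ring carbon is drawn R in compound 2 and S in compound 4 in a structure that otherwise stays the same. The two compounds have the same atoms and bonds and differ only in configuration as drawn.

Neither measured step changes configuration, so neither bears directly on this one. They show only how little the number has moved with changes to the chain. Going by the values given here, with no stereoisomer pair yet measured, no direction can be assigned, and no step beyond the scatter is expected in this assay although the uncertainty is wide. The expected outcome is a 1.1-fold lower number from compound 2 to compound 4 (0.04 log units; within the scatter) on this estimate. For compound 4 the estimated value is 5000 nM with an expected range from 2000 nM to 12000 nM in this assay.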

Compound 4, half-maximal inhibitory concentration: 5700 nM
Estimate against measurement, compound 4: 1.1-fold (0.06 log units) below; measured number inside the range.
By their numbers in this assay, from the lowest: compounds 1, 3, 2 and 4 (each within the scatter of the next, the first and the last beyond it).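

In this assay, inverting both ring stereocentres of compound 2 gives a 1.0-fold higher number from compound 2 to compound 4 (0.02 log units; within the scatter), so the two mirror-drawn ring arrangements are not separated at all on this read-out. Going by these compounds alone, the earlier compounds varied only the chain on the aromatic ring and left the configuration at these two saturated ring carbons untested; this pair adds the first reading of that variable, and for this hex-1-en-1-yl compound the read-out shows no dependence on the joint configuration of the two centres. The comparison is a clean one, with configuration as the only variable in play, and the reading rests on this: the fact that compounds 2 and 4 differ only in the configuration as drawn

Still open, on these data alone, is what a compound with only one of the two stereocentres inverted would give, and whether the same lack of separation holds for the hexyl chain of compound 1 or the longer chain of compound 3. Equally open, as far as these compounds go, is whether the shared core tolerates other changes as readily, for example a carboxylic acid or an amine in place of the hydroxymethyl group.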